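Methyl on one aromatic oxygen of compound 1

A few compounds are considered here, and "the series" means these few. Any claim that something is new, unique, unknown or untested is made for them only; others in the source may bear on it.

Compound 1 `CN(C)CCn1cnnc1-c1cc(Oc2ccc(NC(=O)N/N=C/c3ccc(O)c(O)c3)cc2F)ccn1` carries a 3,4-dihydroxyphenyl group at the end of its acylhydrazone chain. In a functional assay on NCI-H460 cells (Homo sapiens) for cytotoxicity, read by MTT assay, with a stated time of 72 h (on this read-out lower numbers stand for stronger inhibition and higher numbers for weaker inhibition), compound 1 gives 1930 nM, the lowest number among the two compounds measured. Compound 2 `Cn1cnnc1-c1cc(Oc2ccc(NC(=O)N/N=C/c3ccccc3)cc2F)ccn1` differs from compound 1 in several places at once. In this assay, among the compounds with values here, compound 2 gives 15700 nM, a higher number and beyond the usual scatter; no single-point step connects the two, so the pair shows only that compound 1 sits well ahead of compound 2.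

Compound 3 `COc1cc(/C=N/NC(=O)Nc2ccc(Oc3ccnc(-c4nncn4CCN(C)C)c3)c(F)c2)ccc1O` is the next compound to be measured. It differs from compound 1 by methyl in place of hydrogen on an oxygen on an aromatic ring, that is, hydroxy to methoxy, turning the 3,4-dihydroxyphenyl of compound 1 into 4-hydroxy-3-methoxyphenyl.

Within the data shown here, no measured pair in the set isolates this change, so the expectation rests on the small size of the difference. The step of a 1.3-fold higher number from compound 1 to compound 3 (0.13 log units; within the scatter) is expected to be modest and, if anything, toward a slightly higher number, within or close to the scatter. Compound 3 is therefore estimated at 2600 nM in this assay, with a range from 1000 nM to 7000 nM.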

Compound 3, half-maximal inhibitory concentration: 57 nM
Compound 3: middle estimate off by 46-fold (1.66 log units), on the high side; measured number below the stated range.
By their numbers in this assay, from the lowest: compound 3; then compound 1; then compound 2.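

In this assay, hydroxy to methoxy on the 3,4-dihydroxyphenyl group gives a 34-fold lower number from compound 1 to compound 3 (1.53 log units; beyond the scatter), so this oxygen is highly sensitive to a change of a single methyl, and a free hydroxy there is not needed for a low number. Within the data shown here, compound 1 and compound 2 differ in several places at once and could only rank two compounds; this is the first step that ties a large difference to one place, with the rest of the structure unchanged. No measurement on hand accounts for the size of this step.

As far as these compounds go, it remains open whether the low number depends on methyl itself or would persist with ethoxy, a longer alkoxy chain, or fluorine or an amine on the ring at this place, and whether methyl on the other aromatic oxygen, giving 3-hydroxy-4-methoxyphenyl, or on both oxygens, giving 3,4-dimethoxyphenyl, would have a similar effect. Among these compounds, with only one such step, it is also open whether the same change would act similarly on other members.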